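The source may hold more compounds than are shown below. What is called first, only, known or untested is meant among the compounds shown, and "the series" means these compounds.

Compound 1 `COc1ccc(/C=C2\CN(C(=S)SCc3cn(Cc4ccccc4Cl)nn3)C/C(=C\c3ccc(OC)cc3)C2=O)cc1` in a functional assay on 4T1 cells (Mus musculus) for cytotoxicity, read by MTT assay, with a stated time of 24 h (on this read-out lower numbers stand for stronger inhibition and higher numbers for weaker inhibition), gives > 100000 nM, which is a limit of the assay and not a number.
Compound 2 `Cc1ccc(/C=C2\CN(Cc3cn(Cc4cccc(Cl)c4)nn3)C/C(=C\c3ccc(C)cc3)C2=O)cc1` in this assay gives 29300 nM.
Compound 3 `COc1ccc(/C=C2\CN(Cc3cn(Cc4ccccc4Cl)nn3)C/C(=C\c3ccc(OC)cc3)C2=O)cc1` in this assay gives 11400 nM.

Of the two actual numbers, compound 2 has the higher one, which on this read-out stands for the weaker inhibition. Its nearest neighbour is compound 3, whose number is lower by a gap that lies beyond the usual scatter of repeated measurements. Compound 1 sits at a limit and so cannot be ranked against them.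

Compound 4 `Cc1ccc(/C=C2\CN(Cc3cn(Cc4ccc(F)cc4)nn3)C/C(=C\c3ccc(C)cc3)C2=O)cc1` has not yet been measured. It differs from compound 2 in one place: 4-fluorophenyl in place of 3-chlorophenyl on a saturated chain carbon bound to an aromatic nitrogen. For the measured compounds named here, no pair of measured compounds shows this same change, so the data give no direct guide to its size or direction. One halogen-bearing phenyl ring simply takes the place of another, and the rest of the structure, including the shared core, is kept.

For this change the expected step is a 1.1-fold higher number from compound 2 to compound 4 (0.05 log units; within the scatter), which means no shift beyond the usual scatter in either direction. Compound 4 is therefore expected to give about 33000 nM in this assay, with a range from 12000 nM to 95000 nM.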

Compound 4, half-maximal inhibitory concentration: 57200 nM
Beside the measured number, compound 4's estimate is 1.7-fold (0.24 log units) below it; the range from low to high includes it.
By their numbers in this assay, from the lowest: compound 3; then compounds 2 and 4 (each within the scatter of the next). At a limit, above all of these: compound 1.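

In this assay, for the compounds shown here, the swap of 3-chlorobenzyl for 4-fluorobenzyl, with the rest of the molecule kept, gives the first direct reading at this position: a 2.0-fold higher number from compound 2 to compound 4 (0.29 log units; within the scatter). With one halogen-bearing phenyl ring taking the place of another on a saturated chain carbon bound to an aromatic nitrogen, compound 2 and compound 4 cannot be told apart, so this particular swap leaves no effect that can be separated from ordinary repeat-to-repeat variation. Both compounds give actual numbers rather than a limit, which is what allows the step to be read at all, and the read-out does have such a limit: the limit of > 100000 nM in this assay, at which 1 of the 4 values shown sits.

This single step changes the halogen and its ring position together, as the names 3-chlorophenyl and 4-fluorophenyl show, so it cannot say what either change does alone. The compounds shown also leave open what happens at this position when the phenyl ring carries an amine or a carboxylic acid instead of a halogen, or when a longer chain, such as phenylethyl, takes the place of the benzyl group.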